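Isopropyl to ethyl: what compound 3 should show

This account rests on a few compounds, and the source may have more. Where it says the series, first, only, none or still open, it means among the compounds named here.

In an ADME assay for permeability, using PAMPA, with a stated time of 4 h, at pH 7.4 (on this read-out lower numbers stand for lower permeability and higher numbers for higher permeability), compound 1 (`c1ccc2c(c1)CN[C@@H](CN(CCC1CCNCC1)[C@H]1CCCc3cccnc31)C2`) gives 19 nm/s and compound 2 (`CC(C)N1CCN(CCCN(C[C@H]2Cc3ccccc3CN2)[C@H]2CCCc3cccnc32)CC1`) gives 344 nm/s as the higher of the two numbers. Compound 3 (`CCN1CCN(CCCN(C[C@H]2Cc3ccccc3CN2)[C@H]2CCCc3cccnc32)CC1`) differs from compound 2 by hydrogen in place of methyl on a saturated chain carbon bound to an amine nitrogen in a ring and a saturated chain carbon with hydrogen in place of methyl on a saturated chain carbon bound to an amine nitrogen in a ring and a saturated chain carbon, turning isopropyl to ethyl. Within the data shown here, the only measured step, an 18-fold higher number from compound 1 to compound 2 (1.26 log units; beyond the scatter) as large as it is, exchanged a far bigger group and bears on this only loosely, so no shift beyond the scatter is expected in this assay here. The estimated step is a 1.3-fold lower number from compound 2 to compound 3 (0.12 log units; within the scatter) in this read-out. For compound 3 the expected value is 260 nm/s with an estimated range from 120 nm/s to 520 nm/s as its ends.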

Compound 3, apparent permeability: 317 nm/s
For compound 3 the middle estimate is 1.2-fold (0.09 log units) below the measured one, and the stated range covers the measured number.
By their numbers in this assay, from the lowest: compound 1; then compounds 3 and 2 (each within the scatter of the next).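

In this assay, 4-ethylpiperazin-1-yl in place of 4-isopropylpiperazin-1-yl gives a step within the scatter (a 1.1-fold lower number from compound 2 to compound 3 (0.04 log units; within the scatter)), so this methyl can go without a measurable shift. The large difference from the piperidin-4-yl compound also persists with the ethyl group (a 17-fold higher number from compound 1 to compound 3 (1.22 log units; beyond the scatter)), so it does not depend on isopropyl specifically. Nothing available explains why the read-out holds at this position. On these data alone, whether a cyclopropyl, an acetyl or a carboxylic acid-bearing chain in place of the ethyl would leave the number at this level remains open.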